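Swapping the furan on compound 2 for a fluoropyridine

The compounds below may be only part of what the source reports. "The series", "measured", "known", "first", "only" and "open" are said of these compounds alone.

Of the compounds shown here, three sharing one core have been measured in a functional assay on THP-1 cells (Homo sapiens) for inhibition, read by ELISA, with stated times of 1 h and 18 h; on this read-out lower numbers stand for stronger inhibition and higher numbers for weaker inhibition. Compound 1 `NC(=O)[C@@H]1[C@H](Nc2nc(Nc3cccc(C(=O)N4CCCC4)c3)ncc2C2CC2)[C@H]2C=C[C@@H]1C2` carries a cyclopropyl group and gives 90 nM. Compound 2 `NC(=O)[C@@H]1[C@H](Nc2nc(Nc3cccc(C(=O)N4CCCC4)c3)ncc2-c2ccoc2)[C@H]2C=C[C@@H]1C2` carries a furan-3-yl group at the same place and gives 40 nM, the lowest number of the three. Compound 3 `NC(=O)[C@@H]1[C@H](Nc2nc(Nc3cccc(C(=O)N4CCCC4)c3)ncc2-c2ccccc2)[C@H]2C=C[C@@H]1C2` carries a phenyl group there and gives 220 nM. The steps connecting them are all beyond the scatter: a 2.3-fold lower number from compound 1 to compound 2 (0.35 log units; beyond the scatter), a 2.4-fold higher number from compound 1 to compound 3 (0.39 log units; beyond the scatter) and a 5.5-fold higher number from compound 2 to compound 3 (0.74 log units; beyond the scatter).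

Compound 4 `NC(=O)[C@@H]1[C@H](Nc2nc(Nc3cccc(C(=O)N4CCCC4)c3)ncc2-c2ccnc(F)c2)[C@H]2C=C[C@@H]1C2` is not yet measured. It differs from compound 2 in one place: 2-fluoropyridin-4-yl in place of furan-3-yl on an aromatic carbon.

The step that bears most directly on this change is the one in which a six-membered aromatic ring replaced the same furan-3-yl group, a 5.5-fold higher number from compound 2 to compound 3 (0.74 log units; beyond the scatter). For the measured compounds named here, compound 4 also brings a six-membered aromatic ring, so a higher number than compound 2 is expected, though the ring nitrogen and fluorine make compound 4 a different case from compound 3, and no measured step speaks to them. The expected step is a 3.0-fold higher number from compound 2 to compound 4 (0.48 log units; beyond the scatter). Compound 4 is therefore estimated at 120 nM, within a range from 50 nM to 350 nM.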

Compound 4, half-maximal inhibitory concentration: 100 nM
Beside the measured number, compound 4's estimate is 1.2-fold (0.08 log units) above it; low and high end bracket the measured number.
By their numbers in this assay, from the lowest: compound 2; then compounds 1 and 4 (each within the scatter of the next); then compound 3.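

In this assay a six-membered aromatic ring at this position does not by itself set the number: the 2-fluoropyridin-4-yl group gives a clearly lower number than phenyl (a 2.2-fold lower number from compound 3 to compound 4 (0.34 log units; beyond the scatter)). It still does not reach the furan-3-yl group, so compound 2 keeps the lowest number of the four (a 2.5-fold higher number from compound 2 to compound 4 (0.40 log units; beyond the scatter)). Compound 4 and the cyclopropyl compound cannot be told apart (a 1.1-fold higher number from compound 1 to compound 4 (0.05 log units; within the scatter)), which shows that two quite different groups can give matching numbers here.

The ring nitrogen and the fluorine arrive together, so a plain pyridin-4-yl group or a fluorophenyl group would be needed to separate their contributions to the step from phenyl. Nothing available explains why these groups differ.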